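Oxetan-2-yl in place of oxolan-2-yl: outlook for compound 4

The compounds below may be only part of what the source reports. "The series", "measured", "known", "first", "only" and "open" are said of these compounds alone.

Three compounds on the shared core have numbers in a physicochemical assay for lipophilicity, read by HPLC, measured as octanol-water partition, at pH 7.4; a higher number here means a more lipophilic compound, a lower number a more polar compound. Compound 1 (`NC(=O)[C@@H](CCC(F)(F)F)N(C[C@@H]1CCCCO1)S(=O)(=O)c1ccc(Cl)cc1`) gives 4.3, compound 2 (`NC(=O)[C@@H](CCC(F)(F)F)N(CC1CCOCC1)S(=O)(=O)c1ccc(Cl)cc1`) gives 3.5, and compound 3 (`NC(=O)[C@@H](CCC(F)(F)F)N(C[C@@H]1CCCO1)S(=O)(=O)c1ccc(Cl)cc1`) gives 3.5. Compound 3 therefore stands level with compound 2, and the two share the low end of the three numbers.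

The next structure is compound 4 (`NC(=O)[C@@H](CCC(F)(F)F)N(C[C@H]1CCO1)S(=O)(=O)c1ccc(Cl)cc1`), and its difference from compound 3 is oxetan-2-yl in place of oxolan-2-yl on a saturated chain carbon bound to a sulfonamide nitrogen. This is oxetan-2-yl in place of oxolan-2-yl, on a saturated chain carbon bound to a sulfonamide nitrogen.

Going by the values given here, the closest precedent is the step of a number 0.80 log units lower from compound 1 to compound 3 (beyond the scatter), where oxolan-2-yl replaces oxan-2-yl at the same place and the number falls beyond the scatter. The step of a number 0.80 log units lower from compound 1 to compound 2 (beyond the scatter) is of equal size, yet the ring there changes only from oxan-2-yl to oxan-4-yl. The step of no change at the digits printed from compound 2 to compound 3 (within the scatter) is also a reminder that ring size alone does not set the number in this assay. With a single close precedent, a fall somewhat smaller than that one is expected. The expected step is a number 0.50 log units lower from compound 3 to compound 4 (beyond the scatter), downward and probably just beyond the scatter. For compound 4 the estimated value is 3, with an expected range from 2.6 to 3.4.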

Compound 4, distribution coefficient: 2.6
Estimate against measurement, compound 4: 0.40 log units above; low and high end bracket the measured number.
By their numbers in this assay, from the lowest: compound 4; then compounds 2 and 3 (each within the scatter of the next); then compound 1.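

In this assay, the position on a saturated chain carbon bound to a sulfonamide nitrogen still responds when the ring contracts from five-membered to four-membered: the step of a number 0.90 log units lower from compound 3 to compound 4 (beyond the scatter) shows that the fall seen with oxolan-2-yl in place of oxan-2-yl does not stop at compound 3. Along the 2-yl rings, the numbers now fall with each smaller ring from compound 1 through compound 3 to compound 4, ending in the step of a number 1.70 log units lower from compound 1 to compound 4 (beyond the scatter), though compound 2, with oxan-4-yl, goes against any reading by ring size alone, as it stands level with compound 3. The step of a number 0.90 log units lower from compound 2 to compound 4 (beyond the scatter) places compound 4 clear of both compounds at the former low end, so the oxetan-2-yl compound alone holds the lowest number of the four.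

No measurement bearing on the origin of these steps is available, so the trend stays a description of four numbers. Open questions are whether an oxetan-3-yl group, the opposite stereocentre in the oxetan-2-yl group, or an amine at the same place would follow this trend, and whether the steps would hold on a core with a different chain.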